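A 4-Nitrophenyl Swap in a Level Series

The source may report more compounds than this note shows. Statements on the series, on what has been measured and on what is new or still open speak of the compounds shown alone.

Three measured compounds share one core and differ only in the aryl group on a carbon with a double bond to nitrogen. In an ADME assay on HEK293 cells (Homo sapiens) for cytotoxicity (a lower number here means a stronger inhibitor, a higher number a weaker inhibitor), compound 1 (`CCCCCCCCCCCCCCNC(=O)[C@H](CO)/N=C/c1ccc(OC)cc1`) gives 81700 nM and compound 2 (`CCCCCCCCCCCCCCNC(=O)[C@H](CO)/N=C/c1ccccc1Cl`) gives 94900 nM while compound 3 (`CCCCCCCCCCCCCCNC(=O)[C@H](CO)/N=C/c1cccc(Cl)c1`) gives 77000 nM on the same scale. Compound 2 therefore stands level with the other two, within the scatter of each.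

Compound 4 (`CCCCCCCCCCCCCCNC(=O)[C@H](CO)/N=C/c1ccc([N+](=O)[O-])cc1`) is still unmeasured. Its difference from compound 2 is 4-nitrophenyl in place of 2-chlorophenyl on a carbon with a double bond to nitrogen and amounts to 4-nitrophenyl in place of 2-chlorophenyl on a carbon with a double bond to nitrogen.

All three measured steps bear on this change, since they fall at the same place. They are a 1.2-fold higher number from compound 1 to compound 2 (0.07 log units; within the scatter) and a 1.1-fold lower number from compound 1 to compound 3 (0.03 log units; within the scatter) and also a 1.2-fold lower number from compound 2 to compound 3 (0.09 log units; within the scatter) and none of them exceeds the scatter. Among the compounds with values here, no measured compound carries 4-nitrophenyl, so the data offer no direct test of this group, and the range has to stay wide.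

With the aryl group so far making no measurable difference, no step beyond the scatter is expected, and no direction is favoured. The estimated step is a 1.1-fold lower number from compound 2 to compound 4 (0.05 log units; within the scatter) and it stays within the scatter. Compound 4 is estimated at 85000 nM with an expected range of 45000 nM to 150000 nM in this assay for now.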

Compound 4, half-maximal inhibitory concentration: 49500 nM
Beside the measured number, compound 4's estimate is 1.7-fold (0.23 log units) above it; the range from low to high includes it.
By their numbers in this assay, from the lowest: compounds 4, 3, 1 and 2 (each within the scatter of the next).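

In this assay the 4-nitrophenyl group on a carbon with a double bond to nitrogen leaves the series level, with a 1.9-fold lower number from compound 2 to compound 4 (0.28 log units; within the scatter) and a 1.6-fold lower number from compound 3 to compound 4 (0.19 log units; within the scatter) and also a 1.7-fold lower number from compound 1 to compound 4 (0.22 log units; within the scatter) as its steps. The earlier compounds shown here covered only 2-chlorophenyl, 3-chlorophenyl and 4-methoxyphenyl at this position, whereas compound 4 extends the level reading to an aryl group that brings a double bond outside aromatic rings and hydrogen-bond acceptors, and to the direct exchange of nitro in place of methoxy on an aromatic carbon. Nothing on hand offers an explanation for this result.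

The compounds shown leave open whether the level reading would survive a phenyl carrying an amine or a carboxylic acid, or an alkyl group in place of the aryl group at this carbon. They also leave open how a change elsewhere on the shared core, such as a shorter or longer chain, would compare with these aryl exchanges.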